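Lengthening the phenoxy side chain of compound 2 by one carbon

The source may hold more compounds than are shown below. What is called first, only, known or untested is meant among the compounds shown, and "the series" means these compounds.

Three measured compounds share one core. Compound 1 `O=C(O)c1csc([C@H]2CC[C@@H]3[C@@H](/C=C/[C@@H](O)COc4ccccc4)[C@H](O)C[C@@H]3O2)n1` gives 7.9 nM in a functional assay on CHO cells for agonist activity at prostaglandin E2 receptor EP2 subtype (Homo sapiens), read by HTRF and cAMP accumulation, with a stated time of 30 min (a lower number here means that less compound is needed, a higher number that more compound is needed for the effect), compound 2 `O=C(O)c1csc([C@H]2CC[C@@H]3[C@@H](/C=C/COc4ccccc4)[C@H](O)C[C@@H]3O2)n1` gives 3.8 nM in this assay, and compound 3 `O=C(O)c1csc([C@H]2CC[C@@H]3[C@@H](CCOc4ccccc4)[C@H](O)C[C@@H]3O2)n1` gives 1.4 nM in this assay. Compound 2 thus stands second highest of the three numbers, with compound 1 at a higher number and compound 3 at a lower one. Going by the values given here, the one measured step, a 2.1-fold lower number from compound 1 to compound 2 (0.32 log units; beyond the scatter), concerns the loss of a hydroxyl on the chain, not its length.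

Compound 4 `O=C(O)c1csc([C@H]2CC[C@@H]3[C@@H](/C=C/CCOc4ccccc4)[C@H](O)C[C@@H]3O2)n1` differs from compound 2 only in phenoxymethyl in place of phenoxy on a saturated chain carbon bound to a double-bonded chain carbon. Among the compounds with values here, no measured pair tells how a longer chain between the double bond and the phenoxy oxygen is received, so the step is uncertain; small changes across this series have stayed modest, and a modest rise in the number is considered most likely, with the step of a 1.6-fold higher number from compound 2 to compound 4 (0.20 log units; within the scatter) expected for compound 4. Compound 4 is therefore estimated at 6 nM in this assay, in the range 2 nM to 20 nM.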

Compound 4, half-maximal effective concentration: 3.9 nM
Compound 4: middle estimate off by 1.5-fold (0.19 log units), on the high side, within the range that was stated.
By their numbers in this assay, from the lowest: compound 3; then compounds 2 and 4 (each within the scatter of the next); then compound 1.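

In this assay, phenoxymethyl in place of phenoxy on a saturated chain carbon bound to a double-bonded chain carbon gives a 1.0-fold higher number from compound 2 to compound 4 (0.01 log units; within the scatter), so at this position the added carbon produces no change beyond the scatter. The hydroxy can now be judged on a chain of unchanged length: hydrogen in its place gives a 2.0-fold lower number from compound 1 to compound 4 (0.31 log units; beyond the scatter), a modest step beyond the scatter. Nothing available accounts for either step.

The compounds shown leave open whether the tolerance extends to a longer chain, such as 3-phenoxypropyl, or to an amine in place of the phenoxy oxygen. They also leave open how the saturated chain of compound 3 would fare if lengthened by the same carbon.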